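The source may hold more compounds than are shown below. What is called first, only, known or untested is meant among the compounds shown, and "the series" means these compounds.

Compound 1 `Cc1ccccc1OCCCCCn1ccc(=O)[nH]c1=O` gives in an ADME assay on HEL cells (Homo sapiens) for cytotoxicity (a higher number here means that more compound is tolerated, a lower number that less compound is tolerated), the limit > 100000 nM.
Compound 2 `Cc1ccc(OCCCCCn2ccc(=O)[nH]c2=O)cc1` gives in this assay the limit > 100000 nM.

Neither of these is a true number; each only says that the compound was tolerated up to the highest concentration the assay reports, as the limit of > 100000 nM in this assay, at which 2 of the 2 values shown sit, shows. The step that the two limits leave unreadable from compound 1 to compound 2 is therefore unreadable. For the measured compounds named here, compound 2 thus stands exactly where every value so far stands: at the limit, without a measured number of its own.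

Compound 3 `CC(C)(C)c1ccc(OCCCCCn2ccc(=O)[nH]c2=O)cc1` differs from compound 2 by tert-butyl in place of methyl on an aromatic carbon. Going by the values given here, the single measured step, a step that the two limits leave unreadable from compound 1 to compound 2, gives no size, so no measured step with a readable size bears on this change. The expected step of a number no higher from compound 2 to compound 3 (the limit leaves the size open) is accordingly no step beyond the scatter, in no particular direction. Compound 3 is estimated at 100000 nM, within a range from 30000 nM to 300000 nM, with a good chance that it is again reported only as a limit.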

Compound 3, half-maximal cytotoxic concentration: 40000 nM
Estimate against measurement, compound 3: 2.5-fold (0.40 log units) above, and the stated range covers the measured number.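

In this assay, tert-butyl in place of methyl on an aromatic carbon gives an at least 2.5-fold lower number from compound 2 to compound 3 (0.39 log units; beyond the scatter), so this place on the ring can change how much compound the cells tolerate. Compound 2 has only a limit, which means the true step could be larger. Compound 3 is also the first compound here with a real number rather than a limit, giving later changes a value to be read against: the limit of > 100000 nM in this assay, at which 2 of the 3 values shown sit.

As far as these compounds go, the step between compound 1 and compound 2 cannot be read, as both values are limits, so the effect of moving the methyl around the ring stays unknown. From the compounds shown here alone, how an amine or a carboxylic acid at this place, or a longer chain, would fare in this assay also stays open.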